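This account rests on a few compounds, and the source may have more. Where it says the series, first, only, none or still open, it means among the compounds named here.

Measured so far in an ADME assay on Caco-2 cells (Homo sapiens) for permeability, in the apical to basolateral direction; on this read-out lower numbers stand for lower permeability and higher numbers for higher permeability:
compound 1, `Cn1cncc1CN1CC(N(CC2CCN(C(=O)C3CCCC3)CC2)S(=O)(=O)c2ccccn2)Cc2cc(C#N)ccc21`: 0.5 10^-6 cm/s
compound 2, `Cn1cncc1CN1CC(N(CC2CCN(C(=O)c3ccccc3)CC2)S(=O)(=O)c2ccccn2)Cc2cc(C#N)ccc21`: 0.5 10^-6 cm/s
compound 3, `CC(=O)N1CCC(CN(C2Cc3cc(C#N)ccc3N(Cc3cncn3C)C2)S(=O)(=O)c2ccccn2)CC1`: 0.5 10^-6 cm/s

Compound 2 stands level with compounds 1 and 3 at the digits printed in this assay; its nearest neighbour is compound 1, its furthest compound 3, and neither gap reaches beyond the scatter. Compound 4, `Cn1cncc1CN1CC(N(CC2CCN(C(=O)OC(C)(C)C)CC2)S(=O)(=O)c2ccccn2)Cc2cc(C#N)ccc21`, differs from compound 2 by tert-butoxy in place of phenyl on a carbonyl carbon.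

Among the measured compounds shown here, the steps that bear on this change all sit on the same carbonyl carbon: no change at the digits printed from compound 1 to compound 2 (within the scatter), no change at the digits printed from compound 2 to compound 3 (within the scatter) and no change at the digits printed from compound 1 to compound 3 (within the scatter). Across three different groups on that carbon the read-out did not move. The expected step in this assay is therefore no change at the digits printed from compound 2 to compound 4 (within the scatter), none beyond the scatter. Compound 4 is estimated at 0.5 10^-6 cm/s, with a range from 0.25 10^-6 cm/s to 1 10^-6 cm/s.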

Compound 4, apparent permeability: 15.5 10^-6 cm/s
The estimate for compound 4 lay 31-fold (1.49 log units) below the measured number; the measured number lies above the stated range.
By their numbers in this assay, from the lowest: compounds 1, 2 and 3 (each within the scatter of the next); then compound 4.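

In this assay the carbonyl carbon on the amide-type nitrogen in a ring is not the silent position that phenyl, methyl and cyclopentyl made it seem: tert-butoxy gives a 31-fold higher number from compound 2 to compound 4 (1.49 log units; beyond the scatter) and a 31-fold higher number from compound 3 to compound 4 (1.49 log units; beyond the scatter) and likewise a 31-fold higher number from compound 1 to compound 4 (1.49 log units; beyond the scatter) on this read-out. Of the four groups, tert-butoxy alone brings an oxygen onto that carbon, and it alone stands apart. Nothing at hand explains the jump.

Going by these compounds, whether the oxygen or the branched carbons carry the rise stays open. Tert-butyl and methoxy on the same carbon would separate the two.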